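Chloro in place of methylsulfanyl on the compound 1 core

The source may hold more compounds than are shown below. What is called first, only, known or untested is meant among the compounds shown, and "the series" means these compounds.

Among the measured compounds shown here, compound 1 `CSc1[nH]ccc2ncnc1-2` is the only member of the set with a number in a functional assay on the whole organism (Pleural cavity) with Rattus norvegicus as the target; a lower number here means that less compound is needed, a higher number that more compound is needed for the effect: compound 1 gives 9 mg/kg. Compound 2 `[N-]=[N+]=Nc1nccc2c1ncn2C1O[C@H](CO)[C@@H](O)[C@H]1O` gives only a limit of the assay in this assay, namely > 9 mg/kg. For the measured compounds named here, compound 1 therefore stands as the single measured point, the one further value being (the limit of > 9 mg/kg in this assay, at which 1 of the 2 values shown sits).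

Compound 3 `Clc1[nH]ccc2ncnc1-2` has not yet been measured in this assay. It differs from compound 1 by chloro in place of methylsulfanyl on an aromatic carbon. Going by the values given here, with no step between measured compounds known, the size of this change in this assay is open; a step no larger than the usual scatter is expected, in neither direction with confidence, and a further limit rather than a number remains possible. Compound 3 is expected to give about 9 mg/kg in this assay, within 4 mg/kg to 25 mg/kg. This estimate means a step of no change at the digits printed from compound 1 to compound 3 (within the scatter).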

Compound 3, dose for half-maximal effect: > 9 mg/kg
Compound 3 ended at the assay's limit (the forecaster's own chance of this, stated with the estimate: 40%); the middle value lies on the limit itself.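

In this assay compound 3 gives > 9 mg/kg, which is a limit of the assay and not a number. Chloro in place of methylsulfanyl on this aromatic carbon, next to the ring nitrogen, gives a number no lower from compound 1 to compound 3 (the limit leaves the size open), so the change has a direction but no readable size, and compound 1 remains the only member with a number. Limits now outnumber numbers among the compounds shown: the limit of > 9 mg/kg in this assay, at which 2 of the 3 values shown sit.

From the compounds shown here alone, how far compound 3 lies from compound 1 stays open, as does whether any group other than methylsulfanyl gives a number at this position. An amine, a methoxy group or a longer alkylsulfanyl chain on the same carbon would show whether the sulfur atom or the size of the group matters in this assay.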